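A Move from 4-Azidophenyl to 3-Azidophenyl

A few compounds are considered here, and "the series" means these few. Any claim that something is new, unique, unknown or untested is made for them only; others in the source may bear on it.

In a functional assay on U-266 cells (Homo sapiens) for cytotoxicity, read by MTT assay, with a stated time of 72 h (a higher number here means a weaker inhibitor, a lower number a stronger inhibitor), compound 1 (`[N-]=[N+]=Nc1ccc(-c2ccc(/C=C3/C(=O)N(c4ccc(Cl)c(C(=O)O)c4)N=C3C(F)(F)F)o2)cc1`) gives 7030 nM and compound 2 (`O=C(O)c1cc(N2N=C(C(F)(F)F)/C(=C/c3ccc(-c4ccccc4)o3)C2=O)ccc1Cl`) gives 10100 nM as its own reading. These two numbers lie within the usual scatter of each other, so compound 1 does not stand apart from compound 2 on the data so far.

Compound 3 (`[N-]=[N+]=Nc1cccc(-c2ccc(/C=C3/C(=O)N(c4ccc(Cl)c(C(=O)O)c4)N=C3C(F)(F)F)o2)c1`) keeps the shared core of compound 1 and has the same atoms, joined differently. The change is 3-azidophenyl in place of 4-azidophenyl on an aromatic carbon and it sits on an aromatic carbon of a five-membered aromatic ring with 1 oxygen, next to the ring oxygen.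

Among the compounds with values here, no measured pair here shows what such a move does. In this assay no step beyond the scatter is therefore expected, in either direction. That expectation rests only on compound 1 at 7030 nM as the nearest measured structure, so it is a cautious one. The expected step is a 1.0-fold lower number from compound 1 to compound 3 (0.00 log units; within the scatter) and it stays within the scatter. For compound 3 the estimated value is 7000 nM with an expected range from 3000 nM to 15000 nM around it.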

Compound 3, half-maximal inhibitory concentration: 14700 nM
Beside the measured number, compound 3's estimate is 2.1-fold (0.32 log units) below it, and the stated range covers the measured number.
By their numbers in this assay, from the lowest: compounds 1, 2 and 3 (each within the scatter of the next, the first and the last beyond it).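

In this assay, the move of the azide from 4-azidophenyl to 3-azidophenyl, on an aromatic carbon next to the ring oxygen, gives a 2.1-fold higher number from compound 1 to compound 3 (0.32 log units; beyond the scatter), so this position does respond to a change that leaves the atoms the same and only joins them differently, although the step is modest and only just clears the scatter. Compound 2, whose phenyl carries no azide, gives 10100 nM and lies within the scatter of both azides, so the compounds separate only by where the azide sits, and adding the azide is not shown to change the reading in either case. Nothing measured here accounts for the difference between the two placements.

As far as these compounds go, it remains open whether the step belongs to the azide itself or would recur with another group, such as an amine or a carboxylic acid in place of the azide in 3-azidophenyl and 4-azidophenyl. From the compounds shown here alone, it is also open whether the same small gap would appear on other cells or in a readout other than this assay.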